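Swapping the Aryl Group on the Sulfonyl

This account rests on a few compounds, and the source may have more. Where it says the series, first, only, none or still open, it means among the compounds named here.

Compound 1 `COC(=O)c1cc(=O)c2c(OC)cc(OC)cc2n1S(=O)(=O)c1ccc(C)cc1` and compound 2 `COc1ccc(-c2cc(=O)c3c(OC)cc(OC)cc3n2S(=O)(=O)c2c(F)c(F)c(F)c(F)c2F)cc1` share one core, and each carries a sulfonyl group on the aromatic nitrogen of that core. In a functional assay on HepG2 cells (Homo sapiens) for antiproliferative activity, with a stated time of 72 h (a lower number here means that less compound is needed, a higher number that more compound is needed for the effect), compound 1 reaches only the limit of the measurement, > 20000 nM. Compound 2 likewise gives only a limit in this assay, > 34400 nM. Going by the values given here, compound 2 therefore stands at a limit rather than at a number, and the one other value shown is a limit as well; neither compound shows a measurable effect, which is what the limit of > 20000 nM in this assay, at which 1 of the 2 values shown sits, and the limit of > 34400 nM in this assay, at which 1 of the 2 values shown sits, record.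

Compound 3 `COc1ccc(-c2cc(=O)c3c(OC)cc(OC)cc3n2S(=O)(=O)c2ccc(C)cc2)cc1` is compound 2 with a single change: 4-methylphenyl in place of 2,3,4,5,6-pentafluorophenyl on a sulfonyl sulfur. Among the compounds with values here, no step between two measured compounds is available to show how large such a change can be in this assay, so the expectation rests on compound 2 alone. Compound 3 is expected to stay where compound 2 stands, with the expected step from compound 2 to compound 3 being a step that the limit leaves unreadable from compound 2 to compound 3, that is, none beyond the usual scatter. The estimate for compound 3 in this assay is 35000 nM, with a range from 10000 nM to 100000 nM.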

Compound 3, half-maximal effective concentration: > 44800 nM
Compound 3: no number, only a limit; the forecaster's own chance of this, stated with the estimate: 80%; at least 1.2-fold (0.10 log units) between middle value and limit.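

Going by these compounds alone, compound 1, compound 2 and compound 3 all give only limits in this assay, and no step between them can be read. Going by these compounds, whether 4-methylphenyl and 2,3,4,5,6-pentafluorophenyl on a sulfonyl sulfur differ at all in antiproliferative effect stays open, as does what either group would do on a compound that reaches a measurable value.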